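The compounds below may be only part of what the source reports. "The series", "measured", "known", "first", "only" and "open" are said of these compounds alone.

Within the data shown here, in a functional assay on HT-29 cells (Homo sapiens) for cytotoxicity, read by MTT assay, with a stated time of 24 h, tested at 0.64 ug/mL (on this read-out lower numbers stand for a weaker effect and higher numbers for a stronger effect at the one concentration tested), compound 2 `Cn1cnnc1SCC(=O)Nc1ccc(-c2nc(-c3ccccc3)c(-c3ccccc3)n2C)cc1` gives 32%, the higher of the two numbers known so far; compound 1 `Cn1c(-c2ccc(NC(=O)CSc3nc4cc(Cl)ccc4o3)cc2)nc(-c2ccccc2)c1-c1ccccc1` gives 11.9%. Among the measured compounds shown here, the only measured step, a number 20.1 percentage points higher from compound 1 to compound 2 (beyond the scatter), also changed the group on the same sulfur, which is where compound 3 `Cn1nnnc1SCC(=O)Nc1ccc(-c2nc(-c3ccccc3)c(-c3ccccc3)n2C)cc1` differs from compound 2: 1-methyl-1H-tetrazol-5-yl in place of 4-methyl-4H-1,2,4-triazol-3-yl on a sulfur. That earlier step was modest but beyond the scatter; the present exchange keeps the group's size and ring type, so no clear direction is indicated. For compound 3 a step of a number 2 percentage points lower from compound 2 to compound 3 (within the scatter) is expected, within the scatter. Compound 3 is therefore estimated at 30%, between 16% and 46%.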

Compound 3, a percentage reported as activity, at one concentration (the size of the read-out at that concentration, not a potency): 38%
Compound 3: the middle estimate sits 8 percentage points below what was measured; measured number inside the range.
By their numbers in this assay, from the lowest: compound 1; then compounds 2 and 3 (each within the scatter of the next).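

Exchanging 4-methyl-4H-1,2,4-triazol-3-yl for 1-methyl-1H-tetrazol-5-yl on the sulfur gives a number 6 percentage points higher from compound 2 to compound 3 (within the scatter), so this measurement does not separate these two rings. Replacing 5-chloro-1,3-benzoxazol-2-yl with 1-methyl-1H-tetrazol-5-yl gives a number 26.1 percentage points higher from compound 1 to compound 3 (beyond the scatter), so the tetrazole and triazole compounds both read higher than compound 1. No available evidence accounts for these differences. Still open, going by these compounds, is what a carboxylic acid or an amine would give in place of the ring on the sulfur. Also open, on these data alone, is whether a ring without its methyl, such as 1H-tetrazol-5-yl, would give a similar number.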